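Fluoro on the fused ring of compound 2

The compounds below may be only part of what the source reports. "The series", "measured", "known", "first", "only" and "open" are said of these compounds alone.

Three compounds of the series have been run in a functional assay on MCF7 cells (Homo sapiens) for cytotoxicity, read by MTT assay, with a stated time of 72 h; on this read-out higher numbers stand for weaker inhibition and lower numbers for stronger inhibition. Compound 1 `Cc1ccc(-c2ccc(F)cc2)n1-c1ccc(-c2nc3ccccc3s2)cc1` gives 3180 nM, compound 2 `COc1cc(-c2ccc(C)n2-c2ccc(-c3nc4ccccc4s3)cc2)cc(OC)c1OC` gives 4370 nM, and compound 3 `Cc1ccc(-c2ccc([N+](=O)[O-])cc2)n1-c1ccc(-c2nc3ccc(F)cc3s2)cc1` gives 2370 nM. Compound 2 carries the highest number of the three, but its gaps to compound 1 and to compound 3 both lie within the scatter, so no order among them can be read. The next compound is compound 4 `COc1cc(-c2ccc(C)n2-c2ccc(-c3nc4ccc(F)cc4s3)cc2)cc(OC)c1OC`, which differs from compound 2 by fluoro in place of hydrogen on an aromatic carbon. Going by the values given here, no measured pair in this set shares that change, so its effect is not known from the data. The expected step is a 1.2-fold lower number from compound 2 to compound 4 (0.10 log units; within the scatter), no larger than the scatter. Compound 4 is expected to give 3500 nM, in the range 1700 nM to 7500 nM.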

Compound 4, half-maximal inhibitory concentration: 2360 nM
Beside the measured number, compound 4's estimate is 1.5-fold (0.17 log units) above it; measured number inside the range.
By their numbers in this assay, from the lowest: compounds 4, 3, 1 and 2 (each within the scatter of the next).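

This gives the series its first pair differing in one place: in this assay, fluoro in place of hydrogen shows a 1.9-fold lower number from compound 2 to compound 4 (0.27 log units; within the scatter). At this position of compound 2, the change to 6-fluoro-1,3-benzothiazol-2-yl therefore has no effect that can be read from the scatter. No available evidence bears on this result.

Open, as far as these compounds go, is whether another group at this place, such as chloro, methoxy or an amine, would give a step beyond the scatter. Also open, from the compounds shown here alone, is whether fluoro on the fused ring of compound 1 would give a similar step.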